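This account rests on a few compounds, and the source may have more. Where it says the series, first, only, none or still open, it means among the compounds named here.

Measured compounds:
- compound 1, `Cn1nc(Cc2nnc(SCC(=O)Nc3ccc(Cl)cc3Cl)n2CCCO)c2ccccc2c1=O`: > 30000 nM
- compound 2, `Cn1nc(Cc2nnc(SCC(=O)Nc3ccc(Cl)cc3Cl)n2CCC(=O)O)c2ccccc2c1=O`: > 30000 nM
- compound 3, `Cn1c(Cc2nn(CCCO)c(=O)c3ccccc23)nnc1SCC(=O)Nc1ccc(Cl)cc1Cl`: > 30000 nM

Of the compounds shown here, three have so far been tested in an assay on NK92 cells for inhibition of interleukin-2 (Homo sapiens), read by AlphaScreen, with stated times of 30 min and 1 h; on this read-out lower numbers stand for stronger inhibition and higher numbers for weaker inhibition. For compound 1 the result is only a limit of the assay, > 30000 nM, not a number. The same holds for compound 2, whose result is the limit > 30000 nM. Compound 3 likewise gives only the limit > 30000 nM.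

Compound 2 differs from compound 1 in one place: carboxy in place of hydroxymethyl on a saturated chain carbon, two bonds along the chain from an aromatic nitrogen. The step this change made, a step that the two limits leave unreadable from compound 1 to compound 2, cannot be sized, because the limit of > 30000 nM in this assay, at which 3 of the 3 values shown sit, leaves both ends of the step at the same limit.

Compound 3 is built from the same atoms as compound 1, joined differently; the difference between the two cores is not broken down here. The unmeasured compound 4, `Cn1c(Cc2nn(CCC(=O)O)c(=O)c3ccccc23)nnc1SCC(=O)Nc1ccc(Cl)cc1Cl`, stands to compound 3 as compound 2 stands to compound 1: carboxy in place of hydroxymethyl on a saturated chain carbon, two bonds along the chain from an aromatic nitrogen. The two changes are the same, made on cores that differ.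

What to expect from compound 3 to compound 4 in this assay rests on a single earlier example, and that example is unreadable. The estimated step is a step that the limit leaves unreadable from compound 3 to compound 4, chosen because the limit of > 30000 nM in this assay, at which 3 of the 3 values shown sit, shows every value seen so far sitting at the limit. Compound 4 is therefore expected to give about 60000 nM, most likely reported again as a limit, within a range of 20000 nM to 300000 nM.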

Compound 4, half-maximal inhibitory concentration: > 30000 nM
Compound 4: no number, only a limit; the forecaster's own chance of this, stated with the estimate: 90%; the middle value does not contradict the limit.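

In this assay compound 4 gives > 30000 nM, which is a limit of the assay and not a number. No size can be read for the change from compound 3 to compound 4, because both compounds stop at the same limit: the limit of > 30000 nM in this assay, at which 4 of the 4 values shown sit.

The compounds shown leave open whether carboxy in place of hydroxymethyl alters inhibition at all in this assay, on either core.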